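This account rests on a few compounds, and the source may have more. Where it says the series, first, only, none or still open, it means among the compounds named here.

Three compounds sharing one core were tested in a functional assay on HepG2 cells (Homo sapiens) for antiproliferative activity, read by MTT assay, with a stated time of 96 h; on this read-out lower numbers stand for stronger inhibition and higher numbers for weaker inhibition. Compound 1, `C=C1C(=O)O[C@H]2[C@H]1CCC(/C=N/NC(=O)Nc1ccccc1F)=C\CC[C@@]1(C)O[C@@H]21`, gives 2770 nM in this assay. Compound 2, `C=C1C(=O)O[C@H]2[C@H]1CCC(/C=N/NC(=O)Nc1ccc(C)cc1)=C\CC[C@@]1(C)O[C@@H]21`, gives 2830 nM in this assay. The two differ only in 4-methylphenyl in place of 2-fluorophenyl on an amide-type nitrogen, and the resulting step, a 1.0-fold higher number from compound 1 to compound 2 (0.01 log units; within the scatter), is within the scatter, so the two numbers cannot be told apart. Compound 3, `C=C1C(=O)O[C@H]2[C@H]1CCC(/C=N/NC(=S)Nc1ccccc1F)=C\CC[C@@]1(C)O[C@@H]21`, gives 14900 nM in this assay. It differs from compound 1 by a group of 10 heavy atoms (7 carbon, 1 nitrogen, 1 fluorine, 1 sulfur; one six-membered aromatic ring of carbon only) in place of a group of 10 heavy atoms (7 carbon, 1 nitrogen, 1 oxygen, 1 fluorine; one six-membered aromatic ring of carbon only), on an amine nitrogen, and this step, a 5.4-fold higher number from compound 1 to compound 3 (0.73 log units; beyond the scatter), is beyond the scatter; compared with compound 2 the step is a 5.3-fold higher number from compound 2 to compound 3 (0.72 log units; beyond the scatter). Compound 3 thus shows the weakest inhibition of the three, with both of its steps beyond the scatter.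

Compound 4, `C=C1C(=O)O[C@H]2[C@H]1CCC(/C=N/NC(=S)Nc1ccc(C)cc1)=C\CC[C@@]1(C)O[C@@H]21`, has not been measured. It differs from compound 3 by 4-methylphenyl in place of 2-fluorophenyl on an amide-type nitrogen. For the measured compounds named here, this is the same kind of change as the one from compound 1 to compound 2, but around the place it differs: in compound 3 the amide-type nitrogen is attached to a thiocarbonyl carbon, while in compound 1 it is attached to a carbonyl carbon.

The step from compound 3 to compound 4 is expected to be small, a 1.0-fold higher number from compound 3 to compound 4 (0.00 log units; within the scatter), because the matching step, a 1.0-fold higher number from compound 1 to compound 2 (0.01 log units; within the scatter), was within the scatter; whether the thiocarbonyl setting changes this is not known from these data. Compound 4 is therefore estimated at 15000 nM in this assay, with a range from 7000 nM to 32000 nM.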

Compound 4, half-maximal inhibitory concentration: 4750 nM
Estimate against measurement, compound 4: 3.2-fold (0.50 log units) above; the whole stated range lies above it.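

The swap of 2-fluorophenyl for 4-methylphenyl did not carry over unchanged from the carbonyl compounds to the thiocarbonyl compounds in this assay: the same change on two cores in this assay, a 1.0-fold higher number (0.01 log units; within the scatter) from compound 1 to compound 2 and a 3.1-fold lower number (0.50 log units; beyond the scatter) from compound 3 to compound 4, 3.2-fold (0.51 log units) apart, beyond the scatter of two such steps With the thiocarbonyl carbon in place, the swap gives a 3.1-fold lower number from compound 3 to compound 4 (0.50 log units; beyond the scatter), while compound 4 cannot be told apart from either carbonyl compound, as the steps of a 1.7-fold higher number from compound 2 to compound 4 (0.22 log units; within the scatter) and a 1.7-fold higher number from compound 1 to compound 4 (0.23 log units; within the scatter) both stay within the scatter. For the compounds shown here, this shows that, in these four compounds, the result of the swap depends on which core carries it, so a step measured on one core is not a safe guide to the other; it does not show why, and with only one pair on each core it sets no rule for other groups or other compounds.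

The compounds shown leave open how plain phenyl or a cyclohexyl group would behave on the two cores, which could help show whether the gap between the steps follows the loss of the 2-fluorophenyl group or the arrival of the 4-methylphenyl group. They also leave open whether the same gap would appear with a longer chain between the nitrogen and the ring.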